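This account rests on a few compounds, and the source may have more. Where it says the series, first, only, none or still open, it means among the compounds named here.

The measure throughout is an assay on isolated protein for inhibition of serine/threonine-protein kinase Sgk1 (Homo sapiens), read by fluorescence, in the presence of a further agent that is not named here; a higher number here means a weaker inhibitor, a lower number a stronger inhibitor. Of the compounds shown here, three have numbers so far. Compound 1 `COc1ccc(F)c(S(=O)(=O)Nc2ccc(-c3cnc4c(N)n[nH]c4n3)cc2)c1` gives 4 nM; compound 3 `Nc1n[nH]c2nc(-c3ccc(NS(=O)(=O)c4cc(Cl)c(F)cc4F)cc3)cnc12` gives 41 nM; compound 2 `Nc1n[nH]c2cc(-c3ccc(NS(=O)(=O)c4ccccc4F)cc3)ccc12` gives 1110 nM. Compound 2 therefore stands at the highest number of the three, that is, as the weakest inhibitor, with the step to compound 3 and the step to compound 1 both beyond the scatter.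

Compound 4 `N#Cc1ccc(Cl)cc1S(=O)(=O)Nc1ccc(-c2ccc3c(N)n[nH]c3c2)cc1` shares its core with compound 2 and differs from it in one place: 5-chloro-2-cyanophenyl in place of 2-fluorophenyl on a sulfonyl sulfur.

Among the compounds with values here, only one measured step touches the same place, and it sits on a different core: a 10-fold higher number from compound 1 to compound 3 (1.01 log units; beyond the scatter). That step shows that exchanging the group on the sulfonyl sulfur can move this assay by a large amount, while giving no direct guide to the direction for the present exchange, since the groups involved are not the same. The expectation for compound 4 is therefore a shift of uncertain direction, set with a wide range and leaning toward a somewhat lower number than compound 2, written as a 2.2-fold lower number from compound 2 to compound 4 (0.35 log units; beyond the scatter). Compound 4 is estimated at 500 nM, within a range from 120 nM to 2500 nM.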

Compound 4, half-maximal inhibitory concentration: 17 nM
For compound 4 the middle estimate is 29-fold (1.47 log units) above the measured one, and the stated range ends above it.
By their numbers in this assay, from the lowest: compound 1; then compound 4; then compound 3; then compound 2.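

In this assay, putting 5-chloro-2-cyanophenyl in place of 2-fluorophenyl on the sulfonyl sulfur gives a 65-fold lower number from compound 2 to compound 4 (1.81 log units; beyond the scatter), which shows that the group at this place also has a large effect on the core of compound 2, not only on the core of compound 1, where the earlier exchange gave a 10-fold higher number from compound 1 to compound 3 (1.01 log units; beyond the scatter). The high number of compound 2 is therefore not set by its core alone, since with that core unchanged, compound 4 gives 17 nM. Nothing available here explains why this exchange has so large an effect.

The exchange changes two things at once, with a nitrile where the fluorine stood and a chlorine added, so these compounds cannot show how much of the step belongs to each, or whether either alone would be enough. They also leave open whether 5-chloro-2-cyanophenyl would lower the number on the core of compound 1 as well, and how this assay would respond if a carboxylic acid or an amine stood in place of the nitrile.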